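The source may report more compounds than this note shows. Statements on the series, on what has been measured and on what is new or still open speak of the compounds shown alone.

Series so far, in a functional assay on MCF7 cells (Homo sapiens) for antiproliferative activity, read by MTT assay, with a stated time of 48 h; on this read-out higher numbers stand for weaker inhibition and lower numbers for stronger inhibition:
compound 1 `N=C(N)N/N=C(/C=C/c1ccc(Cl)cc1)c1ccccc1`: 700 nM
compound 2 `N=C(N)N/N=C(/C=C/c1ccc(Br)cc1)c1ccccc1`: 250 nM
compound 3 `Cc1ccc(/C=C/C(=N/NC(=N)N)c2ccccc2)cc1`: 16000 nM

Compound 3 stands at the top of this short range with 16000 nM, making it the weakest inhibitor of the three in this assay. The next comparison is with compound 4 `N=C(N)N/N=C(/C=C/c1ccccc1F)c1ccccc1`, which carries 2-fluorophenyl in place of 4-methylphenyl on a double-bonded chain carbon bound to a double-bonded chain carbon.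

The closest evidence comes from the two steps that replace a halogen with methyl, both large: a 23-fold higher number from compound 1 to compound 3 (1.36 log units; beyond the scatter) and a 64-fold higher number from compound 2 to compound 3 (1.81 log units; beyond the scatter). Read backwards, they suggest that leaving the methyl-bearing group could lower the number substantially. The step from chloro to bromo is modest by comparison, a 2.8-fold lower number from compound 1 to compound 2 (0.45 log units; beyond the scatter), but it shows that the identity of the halogen can matter. Going by the values given here, no measured compound carries fluorine or a 2-fluorophenyl group, so these steps transfer only loosely, and a full return to the level of compound 1 or compound 2 is not assumed.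

A sizeable drop, smaller than the two methyl steps, is therefore expected, and the estimated change is an 8.0-fold lower number from compound 3 to compound 4 (0.90 log units; beyond the scatter). For compound 4 the expected value is 2000 nM, with an estimated range from 400 nM to 9000 nM.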

Compound 4, half-maximal inhibitory concentration: 3900 nM
For compound 4 the middle estimate is 2.0-fold (0.29 log units) below the measured one, and the stated range covers the measured number.
By their numbers in this assay, from the lowest: compound 2; then compound 1; then compound 4; then compound 3.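

In this assay, 2-fluorophenyl in place of 4-methylphenyl on a double-bonded chain carbon bound to a double-bonded chain carbon brings a real gain (a 4.1-fold lower number from compound 3 to compound 4 (0.61 log units; beyond the scatter)), so a halogen-bearing group outside the 4-chlorophenyl and 4-bromophenyl pair also improves on compound 3. That gain stops well short of the two earlier halogen compounds (a 5.6-fold higher number from compound 1 to compound 4 (0.75 log units; beyond the scatter); a 16-fold higher number from compound 2 to compound 4 (1.19 log units; beyond the scatter)), which shows that carrying a halogen does not by itself reach their level and that the groups at this place now span a graded order, from 4-bromophenyl through 4-chlorophenyl and 2-fluorophenyl to 4-methylphenyl. No measurement given here accounts for that order.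

Compared with compound 1 and compound 2, compound 4 changes both the halogen and the ring number in the group's name, so these values cannot separate the contribution of fluorine from that of its location on the ring. A 4-fluorophenyl or a 2-chlorophenyl group at this place would separate the two, and a 4-methoxyphenyl group would test whether the order holds beyond halogens and methyl.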